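The source may hold more compounds than are shown below. What is called first, only, known or untested is meant among the compounds shown, and "the series" means these compounds.

In a functional assay on A549 cells (Homo sapiens) for antiproliferative activity, read by MTT assay, with a stated time of 48 h (a lower number here means a stronger inhibitor, a higher number a weaker inhibitor), three close analogues have been measured: compound 1 `C=C(c1ccc(OC)cc1NC(=O)CO)c1ccc(OC)c2c1OC(C)(C)C=C2` (40 nM), compound 2 `C=C(c1ccc(OC)cc1NC(=O)CO)c1ccc(OC)c2c1C=CC(C)(C)O2` (70 nM) and compound 3 `C=C(c1ccc(OC)cc1NC(=O)CN)c1ccc(OC)c2c1OC(C)(C)C=C2` (50 nM). Compound 3 lies within the scatter of both of the others, so its place among them carries no real order. Compound 4 `C=C(c1ccc(OC)cc1NC(=O)CNC)c1ccc(OC)c2c1OC(C)(C)C=C2` keeps the structure of compound 3 apart from one change on the side chain: methyl in place of hydrogen on an amine nitrogen. For the measured compounds named here, only one measured step touches this side chain, and it is not the same change. That step is a 1.3-fold higher number from compound 1 to compound 3 (0.10 log units; within the scatter) (amino in place of hydroxy on a saturated chain carbon bound to a carbonyl carbon), and it stays within the scatter. Going by the values given here, no measured pair shows what a methyl on this nitrogen does, so the evidence is indirect. Resting on a 1.3-fold higher number from compound 1 to compound 3 (0.10 log units; within the scatter) as the only guide, no shift beyond the scatter is expected in this assay and the direction remains open, with a slightly higher number allowed for. An estimated 1.2-fold higher number from compound 3 to compound 4 (0.08 log units; within the scatter) is therefore what is expected here. Compound 4 is estimated at 60 nM with 25 nM to 150 nM as the expected range.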

Compound 4, half-maximal inhibitory concentration: 150 nM
Compound 4: the middle estimate sits 2.5-fold (0.40 log units) below what was measured; measured number inside the range.
By their numbers in this assay, from the lowest: compounds 1, 3 and 2 (each within the scatter of the next); then compound 4.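

In this assay, for the compounds shown here, the amine nitrogen of the side chain proves sensitive to substitution: a 3.0-fold higher number from compound 3 to compound 4 (0.48 log units; beyond the scatter) is the first step on this side chain to lie beyond the scatter, while a 1.3-fold higher number from compound 1 to compound 3 (0.10 log units; within the scatter) stayed within it. The comparison with the hydroxy compound points the same way, with a 3.8-fold higher number from compound 1 to compound 4 (0.57 log units; beyond the scatter) for methylamino in place of hydroxy on the saturated chain carbon bound to the carbonyl carbon, so hydroxy and amino cannot be told apart at this place, whereas methylamino can be, though only modestly. Nothing available bears on why a single added methyl, 1 heavy atom, gives this shift.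

The compounds shown leave open whether the number keeps rising with a larger or further group on this nitrogen, such as ethylamino, dimethylamino or a pyrrolidine ring, or whether the effect stops at the one methyl. They also leave open whether methylamino gives a comparable step on the core of compound 2, and whether an acetamide on this nitrogen, which would replace the amine with an amide, behaves like the methyl.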